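The source may report more compounds than this note shows. Statements on the series, on what has been measured and on what is new or still open speak of the compounds shown alone.

Measured compounds in a functional assay on A549 cells (Homo sapiens) for cytotoxicity, read by MTT assay, with a stated time of 72 h; on this read-out lower numbers stand for stronger inhibition and higher numbers for weaker inhibition:
- compound 1, `Cc1c(C(=O)Nc2ccc(Oc3ccnc4[nH]ccc34)c(F)c2)nnn1-c1ccccc1`, gives 360 nM
- compound 2, `Cc1c(C(=O)Nc2ccc(Oc3ccnc4[nH]ccc34)c(F)c2)nnn1-c1ccccc1F`, gives 390 nM
- compound 3, `Cc1c(C(=O)Nc2ccc(Oc3ccnc4[nH]ccc34)c(F)c2)nnn1-c1ccc(F)c(Cl)c1`, gives 730 nM

Compound 2 stands second highest of the three numbers. Its nearest neighbour is compound 1, reached by a 1.1-fold higher number from compound 1 to compound 2 (0.03 log units; within the scatter), which is within the scatter. The furthest is compound 3, and the step of a 1.9-fold higher number from compound 2 to compound 3 (0.27 log units; within the scatter) is also within the scatter, while a 2.0-fold higher number from compound 1 to compound 3 (0.31 log units; beyond the scatter) is modest and beyond it.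

Compound 4, `Cc1c(C(=O)Nc2ccc(Oc3ccnc4[nH]ccc34)cc2)nnn1-c1ccccc1F`, is not yet measured. It differs from compound 2 by hydrogen in place of fluoro on an aromatic carbon; the carbon sits on a six-membered aromatic ring of carbon only, ortho to a large group and meta to a large group. Going by the values given here, the only measured step that exchanges fluoro and hydrogen on an aromatic carbon is a 1.1-fold higher number from compound 1 to compound 2 (0.03 log units; within the scatter), on a different ring, and it was within the scatter. Among the compounds with values here, no step on the ring of compound 4 concerned has been measured. The step of a 1.0-fold higher number from compound 2 to compound 4 (0.01 log units; within the scatter) is therefore expected to stay within the scatter. Compound 4 is estimated at 400 nM, between 200 nM and 800 nM.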

Compound 4, half-maximal inhibitory concentration: 320 nM
For compound 4 the middle estimate is 1.3-fold (0.10 log units) above the measured one, and the stated range covers the measured number.
By their numbers in this assay, from the lowest: compounds 4, 1, 2 and 3 (each within the scatter of the next, the first and the last beyond it).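

Going by these compounds alone, this is the first step at this carbon, on the ring that carries the amide nitrogen and the ether oxygen, and in this assay it reads a 1.2-fold lower number from compound 2 to compound 4 (0.09 log units; within the scatter). So with the 2-fluorophenyl group in place, fluoro and hydrogen at this carbon cannot be told apart in this assay, which matches the exchange on the other ring, a 1.1-fold higher number from compound 1 to compound 2 (0.03 log units; within the scatter), where the same two atoms also stayed within the scatter. Nothing shown gives a reason why this exchange leaves the reading unresolved.

The compounds shown leave open whether a chloro, methyl or methoxy group on this same carbon would also stay within the scatter. They also leave open whether hydrogen in place of fluoro here reads the same when the 3-chloro-4-fluorophenyl group of compound 3 is present.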